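Cyclopentylamino to 1H-Imidazol-2-yl: An Estimate

The source may hold more compounds than are shown below. What is called first, only, known or untested is meant among the compounds shown, and "the series" means these compounds.

Measured so far:
Compound 1, `Cc1cccnc1-c1ccc(C(=O)Nc2ccc(F)cc2)cc1`: > 4000 nM
Compound 2, `Cc1cccnc1-c1ccc(C(=O)Nc2ccc(C(F)(F)F)cc2)cc1`: 65 nM
Compound 3, `CC(C)(C)c1ccc(NC(=O)c2ccc(-c3ncccc3NC3CCCC3)cc2)cc1`: 190 nM

Of the compounds shown here, three share a core and have been tested in a functional assay for antagonist activity at transient receptor potential cation channel subfamily V member 1 (Homo sapiens), read by FLIPR; a higher number here means a weaker inhibitor, a lower number a stronger inhibitor. Compound 1 reached only a limit of the assay, > 4000 nM, so it gives no number (the limit of > 4000 nM in this assay, at which 1 of the 3 values shown sits). Compound 2 gives 65 nM. Compound 3 gives 190 nM, the higher of the two numbers, with compound 2 as its nearest neighbour.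

Within the data shown here, the one measured step, an at least 61-fold lower number from compound 1 to compound 2 (1.78 log units; beyond the scatter), concerns the group on the outer ring of the amide and sits far from the change now considered.

Compound 4, `CC(C)(C)c1ccc(NC(=O)c2ccc(-c3ncccc3-c3ncc[nH]3)cc2)cc1`, is not yet measured. It differs from compound 3 by 1H-imidazol-2-yl in place of cyclopentylamino on an aromatic carbon. Among the measured compounds shown here, no measured step touches this position, so nothing here tells the direction; the change swaps one donor-and-acceptor group for another of similar size.

Compound 4 is therefore expected near 300 nM, in a range from 80 nM to 1500 nM. The expected step this estimate implies is a 1.6-fold higher number from compound 3 to compound 4 (0.20 log units; within the scatter).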

Compound 4, half-maximal inhibitory concentration: 3670 nM
Beside the measured number, compound 4's estimate is 12-fold (1.09 log units) below it; the whole stated range lies below it.
By their numbers in this assay, from the lowest: compound 2; then compound 3; then compound 4. At a limit, above all of these: compound 1.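

In this assay, this position proves far from indifferent: a 19-fold higher number from compound 3 to compound 4 (1.29 log units; beyond the scatter). The two groups have the same counts of hydrogen-bond donors and acceptors and each holds a five-membered ring, yet the numbers differ widely, so those shared counts alone do not decide the outcome here. The groups still differ in other ways, with a non-aromatic carbon ring attached through a nitrogen in one and an aromatic ring with two hetero atoms in the other, and this single pair cannot show which difference matters.

As far as these compounds go, it remains open how a plain amino group, a methoxy group or a phenyl ring would read at this place. A still weaker compound might give no number, only a limit of the assay, as compound 1 does: the limit of > 4000 nM in this assay, at which 1 of the 4 values shown sits.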